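Notes on inhibition at a single concentration across three analogues

The compounds below may be only part of what the source reports. "The series", "measured", "known", "first", "only" and "open" are said of these compounds alone.

Measured so far:
- compound 1 `NNC(=O)CCc1ccncc1-c1ccc2ccccc2c1`: 102%
- compound 2 `CN1CCN(C(=O)/C=C/c2ccncc2-c2ccc(F)cc2)CC1`: 84%
- compound 3 `CNC(=O)/C=C/c1ccncc1-c1ccc2cnn(C)c2c1`: 99%

In an assay on a protein complex for inhibition of CDK8/Cyclin C (Homo sapiens), with a stated time of 1 h, tested at 10 uM (a lower number here means less inhibition, a higher number more inhibition at the concentration tested (going by the name of the read-out)), compound 1 gives 102%, the highest of the three numbers. Compound 3 sits within the scatter of it, so the two cannot be ordered. Compound 2 lies beyond the scatter below compound 1, and is the only one of the three whose inhibition is clearly lower.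

The unmeasured compound 4 `CN(C)C(=O)/C=C/c1ccncc1-c1ccc2ccccc2c1` shares the core of compound 1 and differs from it in one place: 2-(dimethylcarbamoyl)ethenyl in place of 2-(aminocarbamoyl)ethyl on an aromatic carbon. The group enters on an aromatic carbon of a six-membered aromatic ring with 1 nitrogen, opposite the ring nitrogen. For the measured compounds named here, no step between two measured compounds isolates this change, so the expectation rests on the spread of the three numbers. Compound 3, which also carries an ethenyl amide rather than a saturated chain, reaches 99% in this assay. The step of a number 6 percentage points lower from compound 1 to compound 4 (within the scatter) is therefore expected to be small, if anything slightly downward, and not beyond the scatter. Compound 4 is estimated to give 96% in this assay, with a range from 84% to 104%.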

Compound 4, a percentage reported as inhibition, at one concentration (the size of the read-out at that concentration, not a potency): 100%
Compound 4: middle estimate off by 4 percentage points, on the low side; low and high end bracket the measured number.
By their numbers in this assay, from the lowest: compound 2; then compounds 3, 4 and 1 (each within the scatter of the next).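

In this assay, replacing 2-(aminocarbamoyl)ethyl with 2-(dimethylcarbamoyl)ethenyl on the aromatic carbon opposite the ring nitrogen, ortho to a large group, comes with a number 2 percentage points lower from compound 1 to compound 4 (within the scatter). For the compounds shown here, this is the first direct comparison at this position on the shared core: the group that enters has 0 hydrogen-bond donors against 2 in the group that leaves, 1 hydrogen-bond acceptor against 2, and one more double bond outside aromatic rings, yet the two compounds cannot be told apart at the single concentration tested. No measurement available here explains this outcome.

Going by these compounds alone, the exchange alters the chain and the amide together, so the contribution of the ethenyl link cannot be separated from that of the dimethylamide, and a single-concentration read-out gives no potency for either compound. Open too, on these data alone, is whether the same position would keep this level of inhibition with a carboxylic acid, a primary amine or a longer chain in place of the amide side chain.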